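The source may hold more compounds than are shown below. What is called first, only, known or untested is meant among the compounds shown, and "the series" means these compounds.

Among the measured compounds shown here, compound 3 `N/C(=N\NC(=S)N1CCSCC1)c1ccc(F)cn1` stands second highest of the three numbers so far. In a functional assay on A-375 cells (Homo sapiens) for cytotoxicity, read by MTT assay, with a stated time of 72 h, tested at 100 uM (a lower number here means less inhibition of growth, a higher number more inhibition of growth at the concentration tested), compound 3 gives 83.2%. Its nearest neighbour is compound 2 `N/C(=N\NC(=S)N1CCCC1)c1ccc(F)cn1`, which in this assay gives 86.6%, and the step of a number 3.4 percentage points lower from compound 2 to compound 3 (within the scatter) lies within the scatter. For the measured compounds named here, the furthest is compound 1 `N/C(=N\NC(=S)N1CCOCC1)c1ccccn1`, which in this assay gives 14%; compound 1 differs from compound 3 in more than one place, so no single step is drawn between them.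

The next compound, compound 4 `N/C(=N\NC(=S)N1CCOCC1)c1ccc(F)cn1`, is reached from compound 3 by one change: morpholin-4-yl in place of thiomorpholin-4-yl on a thiocarbonyl carbon. Going by the values given here, the only measured step that bears on this place is the exchange of the ring on the thiocarbonyl carbon, a number 3.4 percentage points lower from compound 2 to compound 3 (within the scatter), which was within the scatter. On that basis a small step in this assay is expected, in no sure direction. The low number of compound 1, which also carries a morpholin-4-yl group but lacks the fluorine of the core, leaves room for doubt, and the range is widened accordingly. Compound 4 is therefore estimated at 70%, between 20% and 92%, which would mean an expected step of a number 13.2 percentage points lower from compound 3 to compound 4 (beyond the scatter).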

Compound 4, percent growth inhibition at one concentration: 86.2%
Estimate against measurement, compound 4: 16.2 percentage points below, within the range that was stated.
By their numbers in this assay, from the lowest: compound 1; then compounds 3, 4 and 2 (each within the scatter of the next).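

In this assay, morpholin-4-yl in place of thiomorpholin-4-yl on a thiocarbonyl carbon gives a number 3 percentage points higher from compound 3 to compound 4 (within the scatter), and morpholin-4-yl in place of pyrrolidin-1-yl at the same place gives a number 0.4 percentage points lower from compound 2 to compound 4 (within the scatter), so on the fluorinated core these three rings cannot be told apart in this read-out. Compound 1 and compound 4 both carry the morpholin-4-yl group. Among the compounds shown here, with that ring held constant, fluoro in place of hydrogen on an aromatic carbon gives a number 72.2 percentage points higher from compound 1 to compound 4 (beyond the scatter), which places the one large step seen so far on the core and not on the thiocarbonyl carbon. Nothing available accounts for the size of that step.

The compounds shown leave open whether pyrrolidin-1-yl and thiomorpholin-4-yl would also match morpholin-4-yl on the core without fluorine, and whether chloro or methoxy could stand in place of the fluoro. They also leave open whether an open-chain group such as dimethylamino on the thiocarbonyl carbon would hold growth inhibition at this level, and whether the three rings would still match at lower concentrations.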